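This account rests on a few compounds, and the source may have more. Where it says the series, first, only, none or still open, it means among the compounds named here.

Measured in an assay on isolated protein for binding affinity to Equilibrative nucleoside transporter 1 (Homo sapiens); on this read-out higher numbers stand for weaker inhibition and lower numbers for stronger inhibition:
- compound 1 `OC[C@H]1O[C@@H](n2cnc3c(SC4CCCCC4)ncnc32)[C@H](O)[C@@H]1O` gives 6310 nM
- compound 2 `Nc1nc(SCc2ccccc2Cl)c2ncn([C@@H]3O[C@H](CO)[C@@H](O)[C@H]3O)c2n1` gives 13500 nM
- compound 3 `CCCn1cnc2c(SC(C)C)nc(N)nc21` gives 145000 nM

Among these three, compound 2 holds the second highest number in this assay. Its nearest neighbour is compound 1, whose lower number lies beyond the scatter of repeated measurements, so compound 1 inhibits more strongly than compound 2. The furthest is compound 3, whose much higher number is also beyond the scatter, so compound 3 is the weakest inhibitor of the three.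

Compound 4 `CC(=O)c1cc(Cl)ccc1Sc1nc(N)nc2c1ncn2[C@@H]1O[C@H](CO)[C@@H](O)[C@H]1O` has not yet been measured. It differs from compound 2 in one place: 2-acetyl-4-chlorophenyl in place of 2-chlorobenzyl on a sulfur. Within the data shown here, no step between two measured compounds exchanges one such group for another, so nothing measured here speaks directly to the size or direction of this change. The account therefore expects no step beyond the usual scatter, with the number for compound 4 staying close to that of compound 2.

Compound 4 is estimated at 11000 nM in this assay, within a range from 3000 nM to 40000 nM. The expected step of a 1.2-fold lower number from compound 2 to compound 4 (0.09 log units; within the scatter) is thus small.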

Compound 4, half-maximal inhibitory concentration: 14500 nM
Beside the measured number, compound 4's estimate is 1.3-fold (0.12 log units) below it; the range from low to high includes it.
By their numbers in this assay, from the lowest: compound 1; then compounds 2 and 4 (each within the scatter of the next); then compound 3.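

In this assay, among these compounds, replacing 2-chlorobenzyl with 2-acetyl-4-chlorophenyl on the sulfur gives a 1.1-fold higher number from compound 2 to compound 4 (0.03 log units; within the scatter), the first step that can be read at this position. Compounds 2 and 4 therefore cannot be told apart on this read-out, even though the entering group carries a hydrogen-bond acceptor that the leaving group lacks and attaches its aromatic ring directly to the sulfur. Nothing available explains why the number stays within the scatter.

This single step does not show whether the position is insensitive to other changes, since both groups carry a chlorine and an aromatic ring of carbon only. From the compounds shown here alone, it remains open whether a group on the sulfur with no such ring, such as a longer alkyl chain, or one bearing an amine or a carboxylic acid, would step beyond the scatter.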